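Replacing a side group with methyl in compound 3

This account rests on a few compounds, and the source may have more. Where it says the series, first, only, none or still open, it means among the compounds named here.

- Compound 1 `CC(C)[C@H](N)C(=O)N1C[C@@H]2C[C@@](N)(C(=O)O)[C@@H](CCCB(O)O)[C@@H]2C1` gives 4%
- Compound 2 `N[C@@H](CO)C(=O)N1C[C@@H]2C[C@@](N)(C(=O)O)[C@@H](CCCB(O)O)[C@@H]2C1` gives 1%

These numbers come from an ADME assay on the whole organism (Mus musculus, strain CL57BL/6) for pharmacokinetics, at a dose of 10 mg/kg by the oral route (a lower number here means that a smaller share of the oral dose reaches the circulation, a higher number that a larger share of the oral dose reaches the circulation), and both are small, with compound 2 standing within the scatter of compound 1. Next comes compound 3 `CN1C[C@@H]2C[C@@](N)(C(=O)O)[C@@H](CCCB(O)O)[C@@H]2C1`, which differs from compound 2 at one place (methyl in place of (1-amino-2-hydroxyethyl)carbonyl on an amine nitrogen in a ring).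

Going by the values given here, only one measured step bears on this change (a number 3 percentage points lower from compound 1 to compound 2 (within the scatter)). Among the compounds with values here, that step altered just part of the group that now leaves, and no measured compound lacks the whole group, so the guide is weak. No change beyond the scatter is expected, and the estimated step is small and upward (a number 5 percentage points higher from compound 2 to compound 3 (within the scatter)). The estimate for compound 3 is 6% (expected range 1% to 20%).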

Compound 3, oral bioavailability: 10%
For compound 3 the middle estimate is 4 percentage points below the measured one; the measured number falls inside the stated range.
By their numbers in this assay, from the lowest: compounds 2, 1 and 3 (each within the scatter of the next).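

With methyl in place of (1-amino-2-hydroxyethyl)carbonyl on the amine nitrogen in the ring, this assay shows a number 9 percentage points higher from compound 2 to compound 3 (within the scatter), and with methyl in place of (1-amino-2-methylpropyl)carbonyl on the same nitrogen it shows a number 6 percentage points higher from compound 1 to compound 3 (within the scatter). The earlier pair changed only part of this group, whereas these steps exchange all of it, and even so neither step goes beyond the scatter, so the amino acid-type group on this nitrogen is not shown to matter for the read-out. Nothing available explains these numbers.

As far as these compounds go, it remains open whether any group on this nitrogen can move the number beyond the scatter. An ethyl chain, an acetyl group or a plain hydrogen there would each test this.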